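Capping the phenol of compound 2 with a vinyl group

The source may hold more compounds than are shown below. What is called first, only, known or untested is meant among the compounds shown, and "the series" means these compounds.

Compound 2 `COc1ccc(Cn2c(-c3ccccc3O)c(Br)c3cc(C)ccc3c2=O)cc1` gives 24500 nM in a functional assay on HL-60 cells (Homo sapiens) for cytotoxicity, read by sulforhodamine B assay (a higher number here means a weaker inhibitor, a lower number a stronger inhibitor), the higher of the two numbers available; compound 1 `COCOc1ccccc1-c1c(Br)c2ccc(C)cc2c(=O)n1C` gives 17200 nM in this assay, and the two numbers lie within the scatter of each other. Compound 3 `C=COc1ccccc1-c1c(Br)c2cc(C)ccc2c(=O)n1Cc1ccc(OC)cc1` differs from compound 2 by vinyl in place of hydrogen on an oxygen on an aromatic ring. Among the compounds with values here, no comparable step between measured compounds exists, so no change beyond the scatter is expected from compound 2 to compound 3 in this assay, an expected step of a 1.2-fold lower number from compound 2 to compound 3 (0.07 log units; within the scatter). For compound 3 the estimate in this assay is 21000 nM, within 7000 nM to 60000 nM.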

Compound 3, half-maximal inhibitory concentration: 29200 nM
Estimate against measurement, compound 3: 1.4-fold (0.14 log units) below; measured number inside the range.
By their numbers in this assay, from the lowest: compounds 1, 2 and 3 (each within the scatter of the next).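

In this assay, vinyl in place of hydrogen on this oxygen gives a 1.2-fold higher number from compound 2 to compound 3 (0.08 log units; within the scatter), a step within the scatter. The free hydroxy is therefore not required to keep compound 3 level with compound 2 in this assay, and this oxygen tolerates a small capping group. No supporting data bear on the reason for this result.

Still open, from the compounds shown here alone, is whether a longer chain on this oxygen, or one ending in an amine or a carboxylic acid, would move the number beyond the scatter.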